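Cytotoxicity notes on a small amine-substituent series

This account rests on a few compounds, and the source may have more. Where it says the series, first, only, none or still open, it means among the compounds named here.

Measured so far:
compound 1 `CCCCOc1ccc(-c2nc3ncccn3c2NCC2CC2)cc1` — in a toxicity assay on A549 cells (Homo sapiens) for cytotoxicity, read by luminescence and CellTiter-Glo, with a stated time of 48 h (on this read-out lower numbers stand for higher toxicity in this test and higher numbers for lower toxicity in this test), compound 1 gives > 100000 nM, a limit
compound 2 `CCCCOc1ccc(-c2nc3ncccn3c2NCc2ccc(OC)cc2)cc1` — in this assay compound 2 gives 55000 nM

Compound 1 shows only a limit in this assay, (the limit of > 100000 nM in this assay, at which 1 of the 2 values shown sits). For the measured compounds named here, compound 2 is thus the one compound of the pair with an actual number in this assay; the other value is a limit, so its standing rests on a single figure. Going by the values given here, the only measured step is an at least 1.8-fold lower number from compound 1 to compound 2 (0.25 log units; that floor lies within the scatter), and its floor lies within the scatter, so it says little beyond the fact that the aryl-bearing compound fell under the limit.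

Compound 3 `CCCCOc1ccc(-c2nc3ncccn3c2NCc2ccco2)cc1` carries furan-2-yl in place of 4-methoxyphenyl on a saturated chain carbon bound to a nitrogen on an aromatic ring. Among the compounds with values here, this change keeps an aromatic ring on the saturated chain carbon bound to the ring nitrogen, so the step from compound 1 to compound 2 bears on it only loosely; no measured step exchanges one aromatic ring for another at this place. The expectation for compound 3 is therefore a step of a 1.3-fold higher number from compound 2 to compound 3 (0.10 log units; within the scatter) that stays within the scatter, with some lean toward a higher number. The estimate for compound 3 is 70000 nM, with a range from 30000 nM to 200000 nM, and a fair chance that this assay again reports only a limit.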

Compound 3, half-maximal cytotoxic concentration: 78000 nM
Compound 3: the middle estimate sits 1.1-fold (0.05 log units) below what was measured; measured number inside the range.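

In this assay, for the compounds shown here, the step of a 1.4-fold higher number from compound 2 to compound 3 (0.15 log units; within the scatter) is the first exchange of one aromatic ring for another on a saturated chain carbon bound to a nitrogen on an aromatic ring, and it stays within the scatter even though 4-methoxyphenyl has 8 heavy atoms and furan-2-yl has 5. Compound 3 also gives a second actual number with an aromatic ring at this place, so the earlier reading no longer rests on compound 2 alone, though the step of an at least 1.2-fold lower number from compound 1 to compound 3 (0.10 log units; that floor lies within the scatter) gives only a floor and does not show a size for the exchange of cyclopropyl for an aromatic ring. Compound 1 remains a limit, and that sets the bound of the comparison: the limit of > 100000 nM in this assay, at which 1 of the 3 values shown sits.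

Still open, from the compounds shown here alone, is whether any group at this place can move the number in this assay beyond the scatter, for example a carboxylic acid, a piperidine or a longer chain in place of furan-2-yl. The compounds shown all keep the rest of the core of compound 1 unchanged, so they say nothing about how far the number depends on the parts outside this place.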